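This account rests on a few compounds, and the source may have more. Where it says the series, first, only, none or still open, it means among the compounds named here.

Two ureas built on a saturated bicyclic amine and carrying the same fluorophenyl group have been run in a physicochemical assay for solubility, in phosphate buffer, at pH 7.4; a lower number here means a less soluble compound, a higher number a more soluble compound. Compound 1, `O=C(Nc1ccccc1F)NC1CC2CCC1C2`, gives 325000 nM in this assay. Compound 2, `CC1(C)C2CCC1(C)C(NC(=O)Nc1ccccc1F)C2`, gives 225000 nM in this assay; the gap between compound 2 and compound 1 lies within the usual scatter of repeated measurements, so the two numbers cannot be separated.

Compound 3, `CC1(C)[C@H]2CC[C@]1(C)C(NC(=O)Nc1ccccc1F)C2`, is next in this assay. Against compound 2 the change is the two compounds have the same atoms and bonds; at least one stereo element is drawn with a configuration in one of them and without one in the other: 2 of 3 stereo elements differ; a stereocentre at a saturated ring carbon is drawn without a configuration in compound 2 and S in compound 3; a stereocentre at a saturated ring carbon is drawn without a configuration in compound 2 and S in compound 3. No atoms or bonds leave or enter; the difference is only in how two stereocentres at saturated ring carbons are drawn.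

Within the data shown here, no step between two measured compounds exists in this set to draw on. With identical atoms and bonds, the step is expected to be none beyond the scatter: no change at the digits printed from compound 2 to compound 3 (within the scatter) is the estimated move. For compound 3 the expected value in this assay is 225000 nM, with a range from 120000 nM to 420000 nM.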

Compound 3, solubility: 225000 nM
Estimate against measurement, compound 3: no gap at the digits printed; measured number inside the range.
By their numbers in this assay, from the lowest: compounds 2, 3 and 1 (each within the scatter of the next).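

In this assay, among these compounds, the first comparison that changes only how stereocentres are drawn gives no change at the digits printed from compound 2 to compound 3 (within the scatter). No atoms or bonds enter or leave, so this pair isolates the two stereocentres at saturated ring carbons, a question that compounds 1 and 2 could not address. The step does not show that configuration at these centres is irrelevant to the read-out, and it cannot be read as a clean comparison of two defined stereoisomers because of one feature of the pair: the fact that one of compounds 2 and 3 is drawn with a defined configuration and the other without, at the place where they differ

Going by these compounds, it remains open whether the opposite configuration at these two stereocentres would give a number beyond the scatter in this assay. Also open, on these data alone, is whether a group of another kind on the shared core, such as an amine or a carboxylic acid, would separate from compounds 2 and 3 in this assay.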